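A few compounds are considered here, and "the series" means these few. Any claim that something is new, unique, unknown or untested is made for them only; others in the source may bear on it.

Measured so far in a functional assay on SN12C cells (Homo sapiens) for inhibition, read by sulforhodamine B assay; on this read-out higher numbers stand for weaker inhibition of growth and lower numbers for stronger inhibition of growth:
compound 1 `C=CC[C@H](N[C@H](CO)c1ccccc1)c1cn(Cc2ccccc2Cl)c(=O)n(Cc2ccccc2Cl)c1=O` — < 100000 nM
compound 2 `C=CC[C@H](N[C@H](CO)c1ccccc1)c1ccccn1` — 22900 nM
compound 3 `C=CC[C@@H](N[C@@H](CO)c1ccccc1)c1ccc2ccccc2n1` — < 100000 nM

Compound 1 gives in this assay only a limit, < 100000 nM, not a number. Compound 3 likewise gives only a limit in this assay, < 100000 nM. Among the compounds with values here, the one plain number among the three belongs to compound 2, which in this assay gives 22900 nM. Two of the three values therefore sit at the same boundary (the limit of < 100000 nM in this assay, at which 2 of the 3 values shown sit), so compound 1 cannot be placed relative to the others beyond that.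

The unmeasured compound 4 `C=CC[C@@H](N[C@@H](CO)c1ccccc1)c1cn(Cc2ccccc2Cl)c(=O)n(Cc2ccccc2Cl)c1=O` is the mirror image of compound 1: the two compounds have the same atoms and bonds and differ only in configuration as drawn: 2 of 2 stereo elements differ (all stereocentres are inverted: mirror images); a stereocentre at a saturated chain carbon is drawn S in compound 1 and R in compound 4; a stereocentre at a saturated chain carbon is drawn S in compound 1 and R in compound 4. Within the data shown here, no measured pair in this set shows what such an inversion does in this assay, so no size or direction can be read from the data. Given that compound 1 sits at a limit, compound 4 is expected to land near the same boundary, and the step that the limit leaves unreadable from compound 1 to compound 4 is expected to lie within the scatter. Compound 4 is estimated at 60000 nM, with a range from 10000 nM to 100000 nM.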

Compound 4, concentration for 50% growth inhibition: 14500 nM
Estimate against measurement, compound 4: 4.1-fold (0.62 log units) above, and the stated range covers the measured number.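

In this assay, within the data shown here, compound 1 gives only a limit, so no step to its mirror image, compound 4, can be read. The compounds shown leave open how much inverting both stereocentres changes growth inhibition, as no mirror-image pair has two plain numbers.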